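This account rests on a few compounds, and the source may have more. Where it says the series, first, only, none or still open, it means among the compounds named here.

Three members of the shared core have been measured in a functional assay on HepG2 cells (Homo sapiens) for antiproliferative activity, read by MTT assay, with a stated time of 48 h; a higher number here means a weaker inhibitor, a lower number a stronger inhibitor. Compound 1 `N#CC1=C(N)Oc2c(c3nc4ccccc4nc3c3ccccc23)C12C(=O)N(Cc1cnnn1-c1cccc(Br)c1)c1ccccc12` carries a 3-bromophenyl on the aromatic nitrogen. In this assay compound 1 gives only a limit, > 50000 nM. Compound 2 `COc1ccccc1-n1nncc1CN1C(=O)C2(C(C#N)=C(N)Oc3c2c2nc4ccccc4nc2c2ccccc32)c2ccccc21` carries a 2-methoxyphenyl in that place. In this assay compound 2 likewise gives only a limit, > 50000 nM. The step between them is a step that the two limits leave unreadable from compound 1 to compound 2. Compound 3 `N#CC1=C(N)Oc2c(N)cc3nc4ccccc4nc3c2C12C(=O)N(Cc1cnnn1-c1ccc(Cl)cc1)c1ccccc12` carries a 4-chlorophenyl on the aromatic nitrogen. In this assay compound 3 again gives only a limit, > 50000 nM. Within the data shown here, the picture so far is the limit of > 50000 nM in this assay, at which 3 of the 3 values shown sit; no measured member yet yields a number.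

Compound 4 `N#CC1=C(N)Oc2c(N)cc3nc4ccccc4nc3c2C12C(=O)N(Cc1cnnn1-c1cc(Cl)ccc1Cl)c1ccccc12` differs from compound 3 in one place: 2,5-dichlorophenyl in place of 4-chlorophenyl on an aromatic nitrogen. Among the measured compounds shown here, the only measured step at the aromatic nitrogen, a step that the two limits leave unreadable from compound 1 to compound 2, cannot be sized, so no step for this position can be read. With the whole series at the limit, no effect beyond the scatter is expected from this change. Compound 4 is therefore expected to remain at the limit in this assay, estimated at 50000 nM (range 20000 nM to 100000 nM), which means an expected step of a number no higher from compound 3 to compound 4 (the limit leaves the size open).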

Compound 4, half-maximal inhibitory concentration: 33100 nM
Compound 4: the middle estimate sits 1.5-fold (0.18 log units) above what was measured, and the stated range covers the measured number.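

Among these compounds, compound 4 is the first member of the series to give a number in this assay. Among the compounds shown here, exchanging 4-chlorophenyl for 2,5-dichlorophenyl on the aromatic nitrogen gives the first step at this position with a readable floor, an at least 1.5-fold lower number from compound 3 to compound 4 (0.17 log units; that floor lies within the scatter). Compound 3 gives only a limit, so the full size of this step stays unknown, and the rest of the series offers no number to set beside it: the limit of > 50000 nM in this assay, at which 3 of the 4 values shown sit.

Still open, as far as these compounds go, is how an unsubstituted phenyl or a 2,5-dimethoxyphenyl on that nitrogen would read against the 2,5-dichlorophenyl of compound 4. Also open, from the compounds shown here alone, is whether 2,5-dichlorophenyl gives a number on the core of compound 1.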